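Adding a Third Methoxy to the Ketone Aryl of Compound 1

This account rests on a few compounds, and the source may have more. Where it says the series, first, only, none or still open, it means among the compounds named here.

Measured so far in a functional assay on OVCAR-8 cells (Homo sapiens) for inhibition, read by sulforhodamine B assay, with a stated time of 48 h; on this read-out higher numbers stand for lower toxicity in this test and lower numbers for higher toxicity in this test:
Compound 1 `COc1ccc(C(=O)/C=C/c2cc(-c3cc(OC)c(OC)c(OC)c3)n[nH]2)cc1OC` gives 5640 nM.
Compound 2 `COc1cc(-c2cc(/C=C/C(=O)c3ccc(F)c(F)c3)[nH]n2)cc(OC)c1OC` gives > 100000 nM, which is a limit of the assay rather than a number.

For the measured compounds named here, compound 1 thus holds the only number in this assay; the other value shown is a limit. The change followed here leads to compound 3 `COc1cc(C(=O)/C=C/c2cc(-c3cc(OC)c(OC)c(OC)c3)n[nH]2)cc(OC)c1OC`: methoxy in place of hydrogen on an aromatic carbon, sitting ortho to a methoxy group and meta to a large group on the ring attached to the carbonyl carbon. Going by the values given here, one measured step touches this same ring: an at least 17-fold higher number from compound 1 to compound 2 (1.24 log units; beyond the scatter), a large loss that ends at the limit (the limit of > 100000 nM in this assay, at which 1 of the 2 values shown sits). That step swapped both methoxy groups for fluorine, whereas the step to compound 3 keeps them and adds a third, so the measured step shows that this ring matters without fixing the direction of the new change. The step from compound 1 to compound 3 is expected to stay roughly within the scatter, leaning toward a lower number: a 1.4-fold lower number from compound 1 to compound 3 (0.15 log units; within the scatter) is the expected step. Compound 3 is therefore estimated at about 4000 nM, within 1000 nM to 20000 nM.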

Compound 3, concentration lethal to 50% of the cells: 6810 nM
For compound 3 the middle estimate is 1.7-fold (0.23 log units) below the measured one, and the stated range covers the measured number.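

In this assay, placing a methoxy group on this aromatic carbon, ortho to a methoxy group and meta to a large group, gives a 1.2-fold higher number from compound 1 to compound 3 (0.08 log units; within the scatter), so compound 1 and compound 3 cannot be told apart. Within this single comparison, the ring attached to the carbonyl carbon takes a third methoxy group with no change beyond the usual scatter, even though the earlier swap of both methoxy groups for fluorine gave an at least 17-fold higher number from compound 1 to compound 2 (1.24 log units; beyond the scatter). The new step is also a reading between two real numbers, whereas that earlier step ends at a limit of the assay rather than a number: the limit of > 100000 nM in this assay, at which 1 of the 3 values shown sits.

Going by these compounds, this result speaks only for methoxy at this position, so it remains open whether an amine, a carboxylic acid or a longer chain such as ethoxy would also leave the read-out unchanged. The step to compound 2 replaced both methoxy groups at once, which leaves open whether one of them counts more than the other.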